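Keeping a tolerated compound tolerated: swapping the distal ring

This account rests on a few compounds, and the source may have more. Where it says the series, first, only, none or still open, it means among the compounds named here.

Measured so far:
compound 1, `CC(CCOc1ccc(-c2nnn(C)n2)cc1)CCN1CCN(c2ccncc2)C1=O`: > 25000 nM
compound 2, `CC(CCOc1ccc(-c2ccc(Cl)cc2)cc1)CCN1CCN(c2ccncc2)C1=O`: > 25000 nM

The read-out is an ADME assay on cells (Homo sapiens) for cytotoxicity; a lower number here means that less compound is tolerated, a higher number that more compound is tolerated. In this assay compound 1 gives > 25000 nM, which is a limit of the assay rather than a number. Compound 2 likewise gives > 25000 nM, again a limit. The step that the two limits leave unreadable from compound 1 to compound 2 therefore cannot be sized, and the only firm point is the limit of > 25000 nM in this assay, at which 2 of the 2 values shown sit. Compound 2 thus stands at the upper edge of what this assay can report, with no numbered value to place it more finely.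

Compound 3 is `Cc1nc(-c2ccc(OCCC(C)CCN3CCN(c4ccncc4)C3=O)cc2)no1`. Against compound 2 the change is 5-methyl-1,2,4-oxadiazol-3-yl in place of 4-chlorophenyl on an aromatic carbon. No measured step can be read in size here, but the two limits show that a small aromatic heterocycle in this position, as in compound 1, and a chlorinated phenyl ring, as in compound 2, both leave the molecule tolerated up to the ceiling of this assay. Compound 3 is therefore expected to sit at that ceiling too, estimated at 40000 nM with a range of 20000 nM to 100000 nM. The expected step is a step that the limit leaves unreadable from compound 2 to compound 3, nothing beyond the scatter.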

Compound 3, half-maximal cytotoxic concentration: > 6250 nM
Compound 3: only a limit was reported (the forecaster's own chance of this, stated with the estimate: 85%); the middle value does not contradict the limit.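

In this assay compound 3 gives > 6250 nM, which is a limit and not a number. Going by these compounds alone, no step between compound 1, compound 2 and compound 3 can be read, as each has only a limit. The compounds shown leave open where each truly stands and whether swapping the distal ring changes tolerance at all.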